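A 4-bromophenyl swap on the amine nitrogen

This account rests on a few compounds, and the source may have more. Where it says the series, first, only, none or still open, it means among the compounds named here.

Measured in a functional assay, with a stated time of 6 min; a higher number here means a weaker inhibitor, a lower number a stronger inhibitor:
- compound 1 `CCOc1ccccc1NCn1nc(-c2ccc3c(c2)OCCO3)oc1=S`: 5280 nM
- compound 2 `Fc1cccc(F)c1NCn1nc(-c2ccc3c(c2)OCCO3)oc1=S`: 3320 nM
- compound 3 `S=c1oc(-c2ccc3c(c2)OCCO3)nn1CNc1ccccc1Cl`: 7230 nM

On these numbers, a 1.4-fold higher number from compound 1 to compound 3 (0.14 log units; within the scatter), whereas a 2.2-fold higher number from compound 2 to compound 3 (0.34 log units; beyond the scatter). Compound 3 therefore cannot be told apart from compound 1, but it reads as a weaker inhibitor than compound 2.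

Compound 4 `S=c1oc(-c2ccc3c(c2)OCCO3)nn1CNc1ccc(Br)cc1` carries 4-bromophenyl in place of 2-chlorophenyl on an amine nitrogen. The closest evidence comes from the other changes at that nitrogen. Besides the two steps above, a 1.6-fold lower number from compound 1 to compound 2 (0.20 log units; within the scatter). All three steps are small, and only one lies beyond the scatter. Going by the values given here, no measured compound carries a bromo group, so the data set no firm direction. In this assay, a modest step at most is therefore expected, quite possibly none beyond the scatter. The expected step is a 1.4-fold lower number from compound 3 to compound 4 (0.16 log units; within the scatter). For compound 4 the estimated value is 5000 nM, with an expected range of 2000 nM to 13000 nM.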

Compound 4, half-maximal inhibitory concentration: 14700 nM
For compound 4 the middle estimate is 2.9-fold (0.47 log units) below the measured one, outside the stated range (above it).
By their numbers in this assay, from the lowest: compounds 2, 1 and 3 (each within the scatter of the next, the first and the last beyond it); then compound 4.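

In this assay, 4-bromophenyl on the amine nitrogen gives the weakest inhibitor of the four, with every step to it beyond the scatter (a 2.0-fold higher number from compound 3 to compound 4 (0.31 log units; beyond the scatter); a 2.8-fold higher number from compound 1 to compound 4 (0.44 log units; beyond the scatter); a 4.4-fold higher number from compound 2 to compound 4 (0.65 log units; beyond the scatter)). The earlier changes at this nitrogen gave at most a modest step, so this position tolerates less change than they suggested, and the widest step now separates 4-bromophenyl from 2,6-difluorophenyl. Nothing measured here explains why the number rises with this change.

The swap moves the halogen's place on the ring and changes chlorine to bromine in a single step, so the compounds shown cannot tell these two changes apart. A 4-chlorophenyl or a 2-bromophenyl group would separate them, and an unsubstituted phenyl ring would show how the ring behaves with no group on it at all.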